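The source may hold more compounds than are shown below. What is called first, only, known or untested is meant among the compounds shown, and "the series" means these compounds.

In an ADME assay on HEK293 cells (Homo sapiens) for cytotoxicity, read by sulforhodamine B assay, with a stated time of 48 h, tested at 10 uM (on this read-out lower numbers stand for less inhibition and higher numbers for more inhibition at the one concentration tested (going by the name of the read-out)), compound 2, with the structure `CCCCCc1cn(C(c2ccccc2)c2cc3cc(Br)ccc3nc2OC)nn1`, gives -2%. Within the data shown here, its only measured neighbour, compound 1, with the structure `CCCCCCc1cn(C(c2ccccc2)c2cc3cc(Br)ccc3nc2OC)nn1`, gives -3.17% in this assay, and the two values lie within the scatter of each other: the step of a number 1.2 percentage points higher from compound 1 to compound 2 (within the scatter) is too small to count, so compound 2 stands together with compound 1 near a reading of no inhibition, with nothing yet seen that moves the number.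

Compound 3, with the structure `COc1nc2ccc(Br)cc2cc1C(c1ccccc1)n1cc(-c2ccc(OC(F)(F)F)cc2)nn1`, carries one change against compound 2: 4-(trifluoromethoxy)phenyl in place of pentyl on an aromatic carbon. Among the measured compounds shown here, no measured step touches this change, since the one step known, from compound 1 to compound 2, only shortens the saturated chain by a single carbon and stays within the scatter. There is therefore no ground for expecting a move in either direction in this assay beyond the scatter, and the step of a number 4 percentage points higher from compound 2 to compound 3 (within the scatter) is expected to be small.

Compound 3 is accordingly estimated to give about 2% in this assay, with a likely range from -12% to 18%.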

Compound 3, a percentage reported as inhibition, at one concentration (the size of the read-out at that concentration, not a potency): 5.8%
Estimate against measurement, compound 3: 3.8 percentage points below; measured number inside the range.
By their numbers in this assay, from the lowest: compounds 1, 2 and 3 (each within the scatter of the next).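

On the aromatic carbon of the five-membered ring, a saturated chain can give way to an aromatic ring carrying a trifluoromethoxy group with no clear effect on the reading: in this assay the swap of pentyl for 4-(trifluoromethoxy)phenyl gives a number 7.8 percentage points higher from compound 2 to compound 3 (within the scatter) and so cannot be told apart from ordinary repeat variation. The comparison with the longer chain agrees, since putting 4-(trifluoromethoxy)phenyl in place of hexyl gives a number 9 percentage points higher from compound 1 to compound 3 (within the scatter) in this assay and again stays inside that variation, so this position has now taken both chains and an aromatic ring with all three compounds reading alike at the one concentration tested. Nothing available here explains why these readings stay together, and no further data bear on this change.

On these data alone, whether a group of another kind on the same carbon, such as an amine or a carboxylic acid, would give a reading clearly apart from these three remains open. So does the role of the trifluoromethoxy group itself, which a plain phenyl at this position would help to separate from that of the aromatic ring.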